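The compounds below may be only part of what the source reports. "The series", "measured", "known", "first", "only" and "open" are said of these compounds alone.

Compound 2 `OC[C@H]1OC(n2cnc3c(-c4nccs4)ncnc32)[C@H](O)[C@@H]1O` gives 2730 nM in a functional assay on CCRF-CEM cells (Homo sapiens) for inhibition (a lower number here means a stronger inhibitor, a higher number a weaker inhibitor), the highest of the two numbers recorded, though within the scatter of compound 1 `Cc1ccsc1-c1ncnc2c1ncn2C1O[C@H](CO)[C@@H](O)[C@H]1O`, which gives 2500 nM. Within the data shown here, the only measured step, a 1.1-fold higher number from compound 1 to compound 2 (0.04 log units; within the scatter), swaps one five-membered heteroaryl ring for another and leaves the number essentially unchanged. Compound 3 `Cn1nccc1-c1ncnc2c1ncn2C1O[C@H](CO)[C@@H](O)[C@H]1O` makes a change of the same kind: 1-methyl-1H-pyrazol-5-yl in place of 1,3-thiazol-2-yl on an aromatic carbon. With just one comparable step to go on, no step beyond the scatter is expected, so a 1.1-fold higher number from compound 2 to compound 3 (0.04 log units; within the scatter) is the estimate. Compound 3 is therefore expected to give about 3000 nM, between 1200 nM and 7500 nM.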

Compound 3, half-maximal inhibitory concentration: "not active" (no number reported)
Nothing numeric was reported for compound 3; there is nothing to compare the estimate with.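

Among these compounds, compound 3 is recorded as not active in this assay without a number, so no step from compound 2 to compound 3 can be read. Nothing shown offers a reason for that record. As far as these compounds go, how far 1-methyl-1H-pyrazol-5-yl separates from 1,3-thiazol-2-yl in this assay stays open.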